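The compounds below may be only part of what the source reports. "The series", "measured", "known", "first", "only" and "open" are said of these compounds alone.

Measured so far:
compound 1, `Cc1ccc(-n2cc(-c3ccc(C)c(C(F)(F)F)c3)nn2)cc1Nc1nccc(-c2cccnc2)n1`: in a functional assay on HL-60 cells (Homo sapiens) for inhibition, read by MTT assay, with a stated time of 72 h (a higher number here means a weaker inhibitor, a lower number a stronger inhibitor), compound 1 gives > 30000 nM, a limit of the assay.
compound 2, `Cc1ccc(-c2nnc(-c3ccc(CN4CCN(C)CC4)cc3)o2)cc1Nc1nccc(-c2cccnc2)n1`: in this assay compound 2 gives 570 nM.

Among the compounds with values here, compound 2 holds the only number in the set; the other value is a limit, as noted by the limit of > 30000 nM in this assay, at which 1 of the 2 values shown sits. Compound 3, `Cc1ccc(-c2nnc(-c3ccc(CN4CCN(C)CC4)c(C(F)(F)F)c3)o2)cc1Nc1nccc(-c2cccnc2)n1`, differs from compound 2 by trifluoromethyl in place of hydrogen on an aromatic carbon. Within the data shown here, no measured pair shows a step of this kind, so the data give no direction; the step expected in this assay is a 1.1-fold higher number from compound 2 to compound 3 (0.06 log units; within the scatter), within the scatter. Compound 3 is expected to give 650 nM, between 200 nM and 2500 nM.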

Compound 3, half-maximal inhibitory concentration: 50 nM
Compound 3: middle estimate off by 13-fold (1.11 log units), on the high side; measured number outside the range, below it.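

In this assay, within the data shown here, trifluoromethyl in place of hydrogen, on the aromatic carbon ortho to the (4-methylpiperazin-1-yl)methyl group, gives an 11-fold lower number from compound 2 to compound 3 (1.06 log units; beyond the scatter) and is the first readable step. This position therefore responds to substitution, though the finding rests on a single pair. No measurement shown bears on the cause of this step. As far as these compounds go, whether methyl, chlorine or a nitrile at this carbon gives a similar step remains open. Also open, from the compounds shown here alone, is whether the step persists with morpholine in place of the 4-methylpiperazine.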